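The source may report more compounds than this note shows. Statements on the series, on what has been measured and on what is new or still open speak of the compounds shown alone.

Measured compounds:
Compound 1 `N#Cc1ccc(/C=N/Nc2nc(N)c3ncn([C@@H]4O[C@H](CO)[C@@H](O)[C@H]4O)c3n2)cc1`: 4.1 nM
Compound 2 `Nc1nc(N/N=C/c2cccnc2Cl)nc2c1ncn2[C@@H]1O[C@H](CO)[C@@H](O)[C@H]1O`: 4.6 nM

In an assay on CHO-K1 cells for displacement of a labelled ligand from adenosine receptor A1 (Homo sapiens), read by scintillation counting, with a stated time of 60 min (on this read-out higher numbers stand for weaker inhibition and lower numbers for stronger inhibition), compound 1 gives 4.1 nM, and compound 2 gives 4.6 nM. Within the data shown here, the only step seen so far, a 1.1-fold higher number from compound 1 to compound 2 (0.05 log units; within the scatter), shows that swapping one aromatic ring for another on the carbon with a double bond to nitrogen leaves the result unchanged within the scatter, so compound 2 sits alongside compound 1 with no separation between them.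

Compound 3 `CCCCC/C=C/C=C/C=N/Nc1nc(N)c2ncn([C@@H]3O[C@H](CO)[C@@H](O)[C@H]3O)c2n1` differs from compound 2 as follows: a group of 9 heavy atoms (9 carbon; no ring) in place of a group of 7 heavy atoms (5 carbon, 1 nitrogen, 1 chlorine; one six-membered aromatic ring with 1 hetero atom), on a carbon with a double bond to nitrogen. Among the measured compounds shown here, no measured step covers a change of this kind, since the single step seen exchanges one ring for another rather than removing the ring altogether; it therefore offers little guidance, and the open chain is treated as an untested departure from both ring-bearing compounds. A modest weakening is expected, estimated as a 3.3-fold higher number from compound 2 to compound 3 (0.51 log units; beyond the scatter). Compound 3 is accordingly estimated at 15 nM in this assay, with a range from 4 nM to 60 nM.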

Compound 3, inhibition constant: 2 nM
Beside the measured number, compound 3's estimate is 7.5-fold (0.88 log units) above it, and the stated range ends above it.
By their numbers in this assay, from the lowest: compound 3; then compounds 1 and 2 (each within the scatter of the next).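

In this assay the aromatic ring on the carbon with a double bond to nitrogen can be replaced without loss: the open chain of 9 carbon atoms with 2 double bonds gives a lower number than the 2-chloropyridin-3-yl group (a 2.3-fold lower number from compound 2 to compound 3 (0.36 log units; beyond the scatter)) and than the 4-cyanophenyl group (a 2.1-fold lower number from compound 1 to compound 3 (0.31 log units; beyond the scatter)). The exchange of one ring for another had separated nothing, whereas both of these modest steps lie beyond the scatter, so this position can respond to the kind of group placed on it. Nothing measured here accounts for the lower number seen with the chain.

The compounds shown leave open whether the 2 double bonds matter, as no saturated chain of the same length stands among them. They also leave open how a shorter chain, a longer chain, or a chain ending in an amine or a carboxylic acid would compare.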